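The source may report more compounds than this note shows. Statements on the series, on what has been measured and on what is new or still open speak of the compounds shown alone.

Measured in a functional assay on HL60/MX2 cells (Homo sapiens) for antiproliferative activity, read by MTT assay, with a stated time of 48 h; a lower number here means a stronger inhibitor, a higher number a weaker inhibitor:
Compound 1 `CCCn1c(N)c(-c2nc3ccccc3[nH]2)c2nc(C#N)c(C#N)nc21`: > 50000 nM (a limit)
Compound 2 `CN(C)CCCn1c(N)c(-c2nc3ccccc3[nH]2)c2nc(C#N)c(C#N)nc21`: 2390 nM

Going by the values given here, compound 2, at 2390 nM, holds the only true number in this assay. The result for compound 1 is a limit. Compound 3 `CN(C)CCCn1c(N)c(-c2nc3cc(Cl)ccc3[nH]2)c2nc(C#N)c(C#N)nc21` carries one change, chloro in place of hydrogen on an aromatic carbon, turning 1H-benzimidazol-2-yl into 5-chloro-1H-benzimidazol-2-yl. Among the compounds with values here, the sole measured step, an at least 20-fold lower number from compound 1 to compound 2 (1.32 log units; beyond the scatter), was large, but it concerns the dimethylamino group on the chain, which compound 3 keeps, so it sets no size for this change. No shift beyond the scatter is therefore expected, and the estimated step is a 1.3-fold lower number from compound 2 to compound 3 (0.12 log units; within the scatter). Compound 3 is estimated at 1800 nM, with an expected range of 500 nM to 7000 nM.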

Compound 3, half-maximal inhibitory concentration: 5310 nM
Compound 3: middle estimate off by 3.0-fold (0.47 log units), on the low side; measured number inside the range.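

In this assay chloro in place of hydrogen gives a 2.2-fold higher number from compound 2 to compound 3 (0.35 log units; beyond the scatter) and so the first measured size for a change on this six-membered aromatic ring: a modest shift toward weaker inhibition, beyond the scatter. Compound 3 keeps the dimethylamino group and still gives a true number rather than a limit. Nothing among the data shown accounts for this shift. From the compounds shown here alone, whether fluoro, methoxy or an amine on this carbon would shift the number the same way stays open, and so does the effect of chloro on another carbon of this ring.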